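The source may hold more compounds than are shown below. What is called first, only, known or untested is meant among the compounds shown, and "the series" means these compounds.

Compound 3 `COCc1ncnc2c1ncn2[C@@H]1O[C@H](CO)[C@@H](O)[C@H]1O` carries a methoxymethyl group on the shared core. In a functional assay on Huh-7 cells (Homo sapiens) for cytotoxicity, read by MTT assay, with a stated time of 3 days (on this read-out lower numbers stand for higher toxicity in this test and higher numbers for lower toxicity in this test), compound 3 reaches only the limit of the test, > 100000 nM. Compound 2 `OC[C@H]1O[C@@H](n2cnc3c(CSCc4ccccc4)ncnc32)[C@H](O)[C@@H]1O` also reaches only that limit, giving > 100000 nM in this assay. Going by the values given here, compound 1 `CN(Cc1ccccc1)Cc1ncnc2c1ncn2[C@@H]1O[C@H](CO)[C@@H](O)[C@H]1O` is the single compound with a number, 9000 nM in this assay. Compound 4 `O=C(O)CNCc1ncnc2c1ncn2[C@@H]1O[C@H](CO)[C@@H](O)[C@H]1O` differs from compound 3 by (carboxymethyl)amino in place of methoxy on a saturated chain carbon bound to an aromatic carbon. Among the compounds with values here, the steps that bear on this are an at least 11-fold higher number from compound 1 to compound 3 (1.04 log units; beyond the scatter) and an at least 11-fold higher number from compound 1 to compound 2 (1.04 log units; beyond the scatter), while the step between compound 2 and compound 3 cannot be read because of the limit of > 100000 nM in this assay, at which 2 of the 3 values shown sit. Compound 4 keeps an amino group on the chain, as compound 1 with 9000 nM does, but lacks its benzyl, so the expected step is a number no higher from compound 3 to compound 4 (the limit leaves the size open). Compound 4 is thus estimated at 100000 nM, between 30000 nM and 300000 nM, probably again as a limit.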

Compound 4, half-maximal cytotoxic concentration: > 100000 nM
Compound 4: a limit, no number; the forecaster's own chance of this, stated with the estimate: 75%; the middle value lies on the limit itself.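

An amino group on this chain carbon is not enough on its own to give a number in this assay: (carboxymethyl)amino in place of benzyl(methyl)amino gives an at least 11-fold higher number from compound 1 to compound 4 (1.04 log units; beyond the scatter). Of the two amino compounds, only compound 1, which carries the benzyl, has a number. The steps from compound 2 and from compound 3 to compound 4 cannot be read: the limit of > 100000 nM in this assay, at which 3 of the 4 values shown sit.

On these data alone, it remains open whether a dimethylamino group, with no benzyl and no carboxylic acid, would give a number here. A benzylamino group would show whether the methyl on the nitrogen of compound 1 matters.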